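A few compounds are considered here, and "the series" means these few. Any claim that something is new, unique, unknown or untested is made for them only; others in the source may bear on it.

Measured so far:
compound 1 `C=C[C@@](C)(/C=C/c1ccc(O)c(/C=C/C(=O)OCC)c1)CCC=C(C)C`, 20900 nM in a functional assay on NALM-6 cells (Homo sapiens) for cytotoxicity, with a stated time of 72 h; a higher number here means that more compound is needed for the effect, a lower number that less compound is needed;
compound 2 `CCOC(=O)/C=C/c1cc(/C=C/[C@](C)(/C=C/c2ccc(OC)cc2)CCC=C(C)C)ccc1O`, > 43400 nM in this assay.

In this assay compound 2 gives > 43400 nM, which is a limit of the assay and not a number (the limit of > 43400 nM in this assay, at which 1 of the 2 values shown sits). Compound 1 gives 20900 nM, and the step of an at least 2.0-fold higher number from compound 1 to compound 2 (0.31 log units; beyond the scatter) runs toward more compound being needed. Compound 3 `COc1ccc(/C=C/[C@@](C)(/C=C/c2ccc(O)c(/C=C/C(=O)c3ccccc3)c2)CCC=C(C)C)cc1` differs from compound 2 by phenyl in place of ethoxy on a carbonyl carbon. Among the measured compounds shown here, no measured step covers this change, and compound 2 itself stands only at a limit, so the size of the step in this assay is uncertain. The estimate for compound 3 is 25000 nM, within 8000 nM to 60000 nM. That estimate corresponds to an expected step of an at least 1.7-fold lower number from compound 2 to compound 3 (0.23 log units; that floor lies within the scatter).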

Compound 3, half-maximal effective concentration: > 43400 nM
Compound 3: a limit, no number (the forecaster's own chance of this, stated with the estimate: 35%); middle value at least 1.7-fold (0.23 log units) from the limit.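

Compound 3, like compound 2, stands at a limit of the assay and not at a number, so no step between compound 2 and compound 3 can be read: the limit of > 43400 nM in this assay, at which 2 of the 3 values shown sit.

On these data alone, what phenyl in place of ethoxy on a carbonyl carbon does to the number in this assay remains open.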